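Swapping fluoro for chloro on the benzylidene aryl of compound 1

The source may report more compounds than this note shows. Statements on the series, on what has been measured and on what is new or still open speak of the compounds shown alone.

Going by the values given here, compound 1, `O=C1/C(=C\c2ccc(F)cc2)c2ccccc2N1c1c(Cl)cccc1Cl`, is one of two compounds measured in a functional assay on KB cells (Homo sapiens) for cytotoxicity, read by MTT assay, with a stated time of 72 h (a lower number here means that less compound is needed, a higher number that more compound is needed for the effect), where compound 1 gives 5 ug/mL. The second compound, compound 2, `Cc1ccc2nc(Cl)c(/C=C3\C(=O)N(c4c(Cl)cccc4Cl)c4ccccc43)cc2c1C`, gives 10 ug/mL in this assay, a number that lies within the usual scatter of the value of compound 1, so the two cannot be ranked against each other. Compound 3, `O=C1/C(=C\c2ccc(Cl)cc2)c2ccccc2N1c1c(Cl)cccc1Cl`, has not yet been measured in this assay. It differs from compound 1 in one place, (chloro in place of fluoro on an aromatic carbon), on an aromatic carbon of a six-membered aromatic ring of carbon only. Among the compounds with values here, no measured pair shows what such a change does here. Compound 3 is therefore expected to stay close to compound 1, with a step of a 1.3-fold lower number from compound 1 to compound 3 (0.10 log units; within the scatter) in this assay that need not exceed the scatter. The estimate for compound 3 is 4 ug/mL, with a range from 1.5 ug/mL to 12 ug/mL.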

Compound 3, concentration for half-maximal effect: 2 ug/mL
Compound 3: middle estimate off by 2.0-fold (0.30 log units), on the high side; the measured number falls inside the stated range.
By their numbers in this assay, from the lowest: compound 3; then compounds 1 and 2 (each within the scatter of the next).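

In this assay the change from 4-fluorophenyl to 4-chlorophenyl gives a 2.5-fold lower number from compound 1 to compound 3 (0.40 log units; beyond the scatter) as a modest step, yet one beyond the scatter. Going by these compounds alone, this is the first measured pair, and it shows that the aromatic carbon para to a large group is not indifferent to the halogen it carries: with the rest of compound 1 unchanged, chloro in place of fluoro gives a lower number. Nothing available explains why this single-atom exchange moves the number.

One pair cannot show whether the trend continues with bromo or stops there. Going by these compounds, what a methoxy group, an amine or a carboxylic acid at this carbon would do remains open, as does the result of leaving this carbon with only hydrogen.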